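Removing a Ring-Amine Methyl: Two Parallel Cases

The source may report more compounds than this note shows. Statements on the series, on what has been measured and on what is new or still open speak of the compounds shown alone.

Measured compounds in a functional assay on MCF7 cells (Homo sapiens) for antiproliferative activity, read by MTT assay; on this read-out higher numbers stand for weaker inhibition and lower numbers for stronger inhibition:
compound 1, `c1ccc2c(c1)ccn2-c1nc(N2CCNCC2)nc2ccccc12`: 14.1 ug/mL
compound 2, `CN1CCN(c2nc(-n3ccc4ccccc43)c3ccccc3n2)CC1`: 6 ug/mL
compound 3, `COc1cc(OC)c(-c2nc(N3CCN(C)CC3)nc3ccccc23)c(OC)c1`: 50 ug/mL

Compound 2 and compound 1 share a core and differ in one place, the change being (hydrogen in place of methyl on an amine nitrogen in a ring). That step is a 2.4-fold higher number from compound 2 to compound 1 (0.37 log units; beyond the scatter), so the compound without the methyl inhibits proliferation less strongly.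

Compound 3 carries the same kind of amine ring as compound 2 but a different core; the difference between the two cores is not broken down here. In this assay compound 3 gives 50 ug/mL, the highest of the three numbers, beyond the scatter from both compound 1 and compound 2.

Compound 4, `COc1cc(OC)c(-c2nc(N3CCNCC3)nc3ccccc23)c(OC)c1`, has not yet been measured. Among the compounds with values here, it differs from compound 3 by hydrogen in place of methyl on an amine nitrogen in a ring, the same change, at the same place, as the one from compound 2 to compound 1. Within the data shown here, since the one measured example of this change gave a 2.4-fold higher number from compound 2 to compound 1 (0.37 log units; beyond the scatter), compound 4 is expected to sit somewhat higher than compound 3, a step of about a 2.0-fold higher number from compound 3 to compound 4 (0.30 log units; within the scatter). The expectation rests on a single pair, so the range is kept wide. Compound 4 is estimated at 100 ug/mL, between 50 ug/mL and 250 ug/mL.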

Compound 4, half-maximal inhibitory concentration: 50 ug/mL
Compound 4: the middle estimate sits 2.0-fold (0.30 log units) above what was measured, and the stated range covers the measured number.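

In this assay the exchange of 4-methylpiperazin-1-yl for piperazin-1-yl reads as no change at the digits printed from compound 3 to compound 4 (within the scatter) on one core and as a 2.4-fold higher number from compound 2 to compound 1 (0.37 log units; beyond the scatter) on the other core. Only the second of these steps lies beyond the scatter when taken alone, yet this does not show that the core alters the outcome of the change, and equally the two pairs do not prove that the change carries over unaltered, since a real difference smaller than the scatter could go unseen. What can be said is limited to these two pairs, which are compatible with a single modest effect of removing the methyl and cannot be separated from one another: the same change on two cores in this assay, a 2.4-fold higher number (0.37 log units; beyond the scatter) from compound 2 to compound 1 and no change at the digits printed (within the scatter) from compound 3 to compound 4, 2.4-fold (0.37 log units) apart, within the scatter of two such steps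

The compounds shown leave open how other groups on that same ring nitrogen, such as an ethyl group, an acetyl group or a longer chain, would read in this assay on either core. They also leave open whether the exchange of methyl for hydrogen would give a step of similar size on any core beyond these two, or in any other assay.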